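The source may hold more compounds than are shown below. What is called first, only, known or untested is meant among the compounds shown, and "the series" means these compounds.

Measured in a functional assay on NCI-H1975 cells (Homo sapiens) for inhibition, read by CellTiter-Glo, with a stated time of 72 h; on this read-out higher numbers stand for weaker inhibition of growth and lower numbers for stronger inhibition of growth:
Compound 1 `C=CC(=O)Nc1cc(Nc2ncc(Cl)c(Nc3c(F)cccc3F)n2)c(OC)cc1N1CCN(C)CC1`: 130 nM
Compound 2 `C=CC(=O)Nc1cc(Nc2ncc(Cl)c(NC3CC3)n2)c(OC)cc1N1CCN(C)CC1`: > 10000 nM
Compound 3 `C=CC(=O)Nc1cc(Nc2ncc(Cl)c(Nc3ccccc3NC(=O)C(C)(C)C)n2)c(OC)cc1N1CCN(C)CC1`: 950 nM

Of the two numbers obtained, compound 3 has the higher one and compound 1 the lower. For compound 2 the result is a limit of the assay, (the limit of > 10000 nM in this assay, at which 1 of the 3 values shown sits).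

Compound 4 `C=CC(=O)Nc1cc(Nc2ncc(Cl)c(Nc3ccccc3S(=O)(=O)N(C)C)n2)c(OC)cc1N1CCN(C)CC1` differs from compound 3 by dimethylsulfamoyl in place of ((tert-butyl)carbonyl)amino on an aromatic carbon. Among the measured compounds shown here, the one measured step, an at least 76-fold higher number from compound 1 to compound 2 (1.88 log units; beyond the scatter), exchanges the whole aromatic ring for cyclopropyl; in the move to compound 4 the ring stays and only the group attached to it changes, so that step offers little guidance here. The step of a 1.1-fold lower number from compound 3 to compound 4 (0.02 log units; within the scatter) is therefore expected to stay within the scatter of this assay. Compound 4 is estimated at 900 nM, with a range from 300 nM to 3000 nM.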

Compound 4, concentration for 50% growth inhibition: 31 nM
For compound 4 the middle estimate is 29-fold (1.46 log units) above the measured one; the measured number lies below the stated range.
By their numbers in this assay, from the lowest: compound 4; then compound 1; then compound 3. At a limit, above all of these: compound 2.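

In this assay, keeping the aromatic ring and changing only the group on it has a large effect, with a 31-fold lower number from compound 3 to compound 4 (1.49 log units; beyond the scatter), so this position is sensitive to what it carries. Exchanging one whole ring for another gives a smaller change, with a 4.2-fold lower number from compound 1 to compound 4 (0.62 log units; beyond the scatter). The comparison with the cyclopropyl compound, an at least 320-fold lower number from compound 2 to compound 4 (2.50 log units; beyond the scatter), rests on a limit for compound 2: the limit of > 10000 nM in this assay, at which 1 of the 4 values shown sits.

Which part of dimethylsulfamoyl matters remains open. So does whether methylsulfonyl, an unsubstituted sulfonamide or a simple amine on the same carbon would give a similar result.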